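This account rests on a few compounds, and the source may have more. Where it says the series, first, only, none or still open, it means among the compounds named here.

In a functional assay on KYSE-450 cells (Homo sapiens) for inhibition, read by MTT assay, with a stated time of 48 h (on this read-out lower numbers stand for stronger inhibition and higher numbers for weaker inhibition), two compounds sharing one core have been measured so far. Compound 1 `CCCCC(=O)N(Cc1ccc(OC)c(O)c1)c1cc(OC)c(OC)c(OC)c1` gives 300 nM, while compound 2 `C/C=C/C(=O)N(Cc1ccc(OC)c(O)c1)c1cc(OC)c(OC)c(OC)c1` gives 67 nM, the lower of the two numbers. Among the compounds with values here, the only measured step is a 4.5-fold lower number from compound 1 to compound 2 (0.65 log units; beyond the scatter), and it lies beyond the scatter, with prop-1-en-1-yl in place of butyl on a carbonyl carbon. Compound 3 `COc1ccc(CN(C(=O)CCCCCl)c2cc(OC)c(OC)c(OC)c2)cc1O` differs from compound 2 at that same place: 4-chlorobutyl in place of prop-1-en-1-yl on a carbonyl carbon. Here 4-chlorobutyl stands in place of prop-1-en-1-yl on a carbonyl carbon, so the double bond outside the aromatic rings leaves. The 4-chlorobutyl chain has no such double bond, and neither does the butyl chain of compound 1, which gives 300 nM. The measured step therefore bears on this change when read in reverse, although no measurement shows what the chlorine contributes. The expected change is a 3.7-fold higher number from compound 2 to compound 3 (0.57 log units; beyond the scatter), a modest move to a higher number of about the size of the measured step. For compound 3 the estimated value in this assay is 250 nM, with an expected range of 80 nM to 800 nM.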

Compound 3, half-maximal inhibitory concentration: 770 nM
Beside the measured number, compound 3's estimate is 3.1-fold (0.49 log units) below it; low and high end bracket the measured number.
By their numbers in this assay, from the lowest: compound 2; then compound 1; then compound 3.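

In this assay, the place on the carbonyl carbon now has a second saturated chain to set against prop-1-en-1-yl, and the step is large: an 11-fold higher number from compound 2 to compound 3 (1.06 log units; beyond the scatter). The earlier compounds shown here could say nothing about the chlorine, but its part can now be read apart from the loss of the double bond, with a 2.6-fold higher number from compound 1 to compound 3 (0.41 log units; beyond the scatter), so chloro on the chain end moves the number further in the same direction rather than staying within the scatter. Among these three compounds, both saturated chains, butyl and 4-chlorobutyl, give higher numbers than the prop-1-en-1-yl chain of compound 2, and none of the three goes against this, although nothing available here explains the order.

The compounds shown leave open whether the lower number of compound 2 goes with the double bond itself or with the shorter chain, a question that a saturated propyl chain on the same carbonyl carbon would address. They also leave open how a longer chain, or an amine or a hydroxyl in place of the chloro at the chain end, would read in this assay.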